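From cyclobutyl to 1-propylazetidin-3-yl on the shared core

The compounds below may be only part of what the source reports. "The series", "measured", "known", "first", "only" and "open" are said of these compounds alone.

Measured in a functional assay on HCT-116 cells (Homo sapiens) for antiproliferative activity, read by MTT assay, with a stated time of 48 h; on this read-out lower numbers stand for stronger inhibition and higher numbers for weaker inhibition
Compound 1 `COc1cc(-c2nnc3c(OC)cc(-c4ccc5c(ccn5C)c4)cn23)cc(OC)c1OC` gives 33 nM
Compound 2 `COc1cc(-c2nnc3c(OC4COC4)cc(-c4ccc5c(ccn5C)c4)cn23)cc(OC)c1OC` gives 1290 nM
Compound 3 `COc1cc(-c2nnc3c(OC4CCC4)cc(-c4ccc5c(ccn5C)c4)cn23)cc(OC)c1OC` gives 750 nM

In this assay compound 3 gives 750 nM and stands with compound 2 at the upper end of the three numbers (a 1.7-fold lower number from compound 2 to compound 3 (0.24 log units; within the scatter)). Compound 1 lies far below both (a 23-fold higher number from compound 1 to compound 3 (1.36 log units; beyond the scatter) and a 39-fold higher number from compound 1 to compound 2 (1.59 log units; beyond the scatter)).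

Compound 4 `CCCN1CC(Oc2cc(-c3ccc4c(ccn4C)c3)cn3c(-c4cc(OC)c(OC)c(OC)c4)nnc23)C1` keeps the core of compound 3 and changes the group on the same oxygen (1-propylazetidin-3-yl in place of cyclobutyl on an oxygen on an aromatic ring). The two large steps both start from methyl, so they say little about replacing one four-membered ring with another. The closer guide is the exchange of oxetan-3-yl for cyclobutyl, which stayed within the scatter. Among the measured compounds shown here, no measured compound carries 1-propylazetidin-3-yl, so this guide is only partial and the range must be wide. In this assay no step beyond the scatter is expected. The estimate amounts to a small expected change (a 1.3-fold higher number from compound 3 to compound 4 (0.12 log units; within the scatter)). For compound 4 the expected value is 1000 nM with an estimated range from 350 nM to 3500 nM in this measurement.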

Compound 4, half-maximal inhibitory concentration: 675 nM
Estimate against measurement, compound 4: 1.5-fold (0.17 log units) above; the range from low to high includes it.
By their numbers in this assay, from the lowest: compound 1; then compounds 4, 3 and 2 (each within the scatter of the next).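

In this assay, among the compounds shown here, 1-propylazetidin-3-yl is the first group on this oxygen to bring a ring nitrogen and a propyl chain, yet neither the step from cyclobutyl (a 1.1-fold lower number from compound 3 to compound 4 (0.05 log units; within the scatter)) nor the step from oxetan-3-yl (a 1.9-fold lower number from compound 2 to compound 4 (0.28 log units; within the scatter)) leaves the scatter. The three four-membered rings therefore cannot be told apart at this position, and all three stand well away from methyl (a 20-fold higher number from compound 1 to compound 4 (1.31 log units; beyond the scatter)). Nothing available explains why these rings read alike or why methyl differs from them.

Still open, from the compounds shown here alone, is whether ethyl, or an open chain ending in an amine such as 2-(dimethylamino)ethyl, would read like methyl or like the rings. Also open, going by these compounds, is how azetidin-3-yl or 1-methylazetidin-3-yl would compare with the 1-propylazetidin-3-yl of compound 4.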